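A Methyl on the Piperidine Ring of Compound 3

A few compounds are considered here, and "the series" means these few. Any claim that something is new, unique, unknown or untested is made for them only; others in the source may bear on it.

Compound 1 `CC1CCN(c2ccc(Nc3ncc4c(n3)N(C3CCCC3)CC(=O)N4)nc2)CC1` gives > 30000 nM in a functional assay on MDA-MB-231 cells (Homo sapiens) for inhibition, read by MTT assay, with a stated time of 48 h (on this read-out lower numbers stand for stronger inhibition and higher numbers for weaker inhibition), which is a limit of the assay and not a number.
Compound 2 `CC1CCN(c2ccc(Nc3ncc4c(n3)N(C3CCCC3)CC(=O)N4C)nc2)CC1` gives > 30000 nM in this assay, again a limit of the assay.
Compound 3 `CCN1C(=O)CN(C2CCCC2)c2nc(Nc3ccc(N4CCCCC4)cn3)ncc21` gives 28200 nM in this assay.

Among the compounds with values here, compound 3 thus holds the only number in this small set; the other two values sit at the limit of > 30000 nM in this assay, at which 2 of the 3 values shown sit. Within the data shown here, the single step between measured compounds, a step that the two limits leave unreadable from compound 1 to compound 2, cannot be read because both of its ends are limits, so no measured step gives a usable size for the change at hand.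

Compound 4 `CCN1C(=O)CN(C2CCCC2)c2nc(Nc3ccc(N4CCC(C)CC4)cn3)ncc21` differs from compound 3 by methyl in place of hydrogen on a saturated ring carbon. Among the measured compounds shown here, compounds 1 and 2 carry the same 4-methylpiperidin-1-yl group as compound 4, but they also differ from compound 3 on the amide-type ring nitrogen, so no single step connects them to compound 3; their values show only that both sit at the limit.

For compound 4 the expected step is estimated as a 1.2-fold higher number from compound 3 to compound 4 (0.09 log units; within the scatter), and there is a fair chance that only a limit is reported. The estimate for compound 4 is 35000 nM, within 14000 nM to 90000 nM.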

Compound 4, half-maximal inhibitory concentration: > 30000 nM
Compound 4 ended at the assay's limit (the forecaster's own chance of this, stated with the estimate: 60%); the middle value is on the limit's open side.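

In this assay compound 4 gives > 30000 nM, which is a limit of the assay and not a number. Putting methyl in place of hydrogen on this saturated ring carbon, which turns piperidin-1-yl into 4-methylpiperidin-1-yl, comes out as an at least 1.0-fold higher number from compound 3 to compound 4 (0.02 log units; that floor lies within the scatter), so this change gives no sign of stronger inhibition, and only a floor for the step is known. The other steps that reach compound 4 cannot be read, with limits at both ends, and the set now gathers at one edge of the assay: the limit of > 30000 nM in this assay, at which 3 of the 4 values shown sit.

On these data alone, whether another group at this place, such as an amine, a carboxylic acid or a longer chain, would bring the number down stays open. As far as these compounds go, how far compound 4 truly lies past its limit also stays open.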